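Compound 1 to compound 3: one change on a carbonyl carbon

The source may report more compounds than this note shows. Statements on the series, on what has been measured and on what is new or still open speak of the compounds shown alone.

- compound 1 `CCNC(=O)Nc1ccc(-c2nc(CS(C)(=O)=O)cc([C@]34CCOC[C@H]3C4)n2)cc1`: 96 ug/mL
- compound 2 `CCNC(=O)Nc1ccc(-c2nc(CS(C)(=O)=O)cc([C@@]34CCOC[C@@H]3C4)n2)cc1`: 77 ug/mL

Both numbers come from a physicochemical assay for solubility, in phosphate buffer, measured as kinetic solubility, with a stated time of 1 h, at pH 7.4; on this read-out lower numbers stand for lower solubility and higher numbers for higher solubility (the only read-out so far). Going by the values given here, compound 1 stands level with compound 2, its only measured neighbour (a 1.2-fold lower number from compound 1 to compound 2 (0.10 log units; within the scatter)). That pair rests on the fact that compounds 1 and 2 differ only in the configuration as drawn (a matter of configuration alone).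

Compound 3 `CNCC(=O)Nc1ccc(-c2nc(CS(C)(=O)=O)cc([C@]34CCOC[C@H]3C4)n2)cc1` carries (methylamino)methyl in place of ethylamino on a carbonyl carbon. Among the compounds with values here, the measured step bears on this only weakly: no measured compound carries the entering group, so that step sets no scale for the change. A moderate rise in this assay is expected from the structural change alone, with a margin wide enough to admit no change beyond the scatter. The estimated move is modest (a 1.6-fold higher number from compound 1 to compound 3 (0.19 log units; within the scatter)). Compound 3 is estimated at 150 ug/mL with an expected range (70 ug/mL to 320 ug/mL).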

Compound 3, solubility: 158 ug/mL
Estimate against measurement, compound 3: 1.1-fold (0.02 log units) below; low and high end bracket the measured number.
By their numbers in this assay, from the lowest: compounds 2, 1 and 3 (each within the scatter of the next, the first and the last beyond it).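

Going by these compounds alone, the earlier pair varied configuration alone; compound 3 is the first change to the group on the carbonyl carbon, and in this assay it gives a step that stays inside the usual scatter (a 1.6-fold higher number from compound 1 to compound 3 (0.22 log units; within the scatter)). At this place, then, (methylamino)methyl can stand in for ethylamino, with the same heavy-atom count and an added hydrogen-bond acceptor, and the read-out does not separate compound 1 from compound 3. Nothing on hand speaks to a cause for this step.

Open, going by these compounds, is whether a tertiary amine such as (dimethylamino)methyl, a carboxylic acid or a longer aminoalkyl chain on this carbonyl carbon would move the number beyond the scatter. Also open, on these data alone, is whether the mirror image of compound 3 would stand level with compound 3, as compound 2 does with compound 1.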